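The compounds below may be only part of what the source reports. "The series", "measured", "known", "first", "only" and "open" are said of these compounds alone.

Going by the values given here, compound 2 `CC1CCN(S(=O)(=O)N2CCN(CC(=O)Nc3cc(Cl)ccc3OC(C)C)CC2)CC1` is one of only two compounds measured in an assay on HEK293 cells for inhibition of potassium channel subfamily T member 1 (Homo sapiens), read by thallium flux; on this read-out higher numbers stand for weaker inhibition and lower numbers for stronger inhibition. There compound 2 gives 5100 nM, while compound 1 `COc1ccc(F)cc1NC(=O)CN1CCN(S(=O)(=O)N2CCC(C)CC2)CC1` gives 4900 nM; the two numbers lie within the usual scatter of each other. Compound 3 `Cc1ccc(Cl)cc1NC(=O)CN1CCN(S(=O)(=O)N2CCC(C)CC2)CC1` has not yet been measured. It differs from compound 2 in one place: methyl in place of isopropoxy on an aromatic carbon. Among the compounds with values here, no measured pair shows the effect of such a change, so no step beyond the scatter is expected in this assay. Compound 3 is therefore expected to give about 5000 nM, within a likely range of 2000 nM to 12000 nM, an expected step of a 1.0-fold lower number from compound 2 to compound 3 (0.01 log units; within the scatter).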

Compound 3, half-maximal inhibitory concentration: > 10000 nM
Compound 3: a limit, no number (the forecaster's own chance of this, stated with the estimate: 10%); middle value at least 2.0-fold (0.30 log units) from the limit.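

Compound 3 reads as a limit, not a number, in this assay: the limit of > 10000 nM in this assay, at which 1 of the 3 values shown sits.

This gives the first view of this position: methyl in place of isopropoxy gives an at least 1.9-fold higher number from compound 2 to compound 3 (0.29 log units; that floor lies within the scatter), and 5-chloro-2-methylphenyl in place of 5-fluoro-2-methoxyphenyl gives an at least 2.0-fold higher number from compound 1 to compound 3 (0.30 log units; that floor lies within the scatter). Methyl on this aromatic carbon therefore brings no stronger inhibition, and the true size of either step remains unknown.

As far as these compounds go, whether ethoxy or a hydroxyl group on this carbon would match compound 2 stays open. So does the effect of any change at the chloro group.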